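The source may hold more compounds than are shown below. What is called first, only, known or untested is meant among the compounds shown, and "the series" means these compounds.

Compound 1 `CC#C[C@@H](Cc1nnn[nH]1)c1ccc(OCc2ccc3scc(-c4cncnc4C)c3c2)cc1`: 37 nM
Compound 2 `CC#C[C@@H](Cc1nnn[nH]1)c1ccc(OCc2ccc3scc(-c4ccc(OCCOC)cc4C)c3c2)cc1`: 9 nM
Compound 3 `CC#C[C@@H](Cc1nnn[nH]1)c1ccc(OCc2ccc3sc(Cl)c(-c4ccccc4C)c3c2)cc1`: 20 nM

In a functional assay on cells for agonist activity at Free fatty acid receptor 1 (Homo sapiens), read by FLIPR and calcium flux (on this read-out higher numbers stand for an effect only at larger amounts of compound and lower numbers for an effect already at smaller amounts), compound 3 stands second highest of the three numbers; compound 1 lies within the scatter of it, while compound 2 gives a number that is lower by more than the scatter. For the measured compounds named here, the only measured step, a 4.1-fold lower number from compound 1 to compound 2 (0.61 log units; beyond the scatter), concerns a swap of one group for another on an aromatic carbon elsewhere in the shared core and does not involve a halogen. Compound 4 `CC#C[C@@H](Cc1nnn[nH]1)c1ccc(OCc2ccc3sc(I)c(-c4ccccc4C)c3c2)cc1` differs from compound 3 by iodo in place of chloro on an aromatic carbon. Going by the values given here, no measured step bears on such an exchange, so there is no basis for expecting a move beyond the scatter in this assay. The expectation for compound 4 is 20 nM, with a range from 8 nM to 50 nM, an expected step of no change at the digits printed from compound 3 to compound 4 (within the scatter).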

Compound 4, half-maximal effective concentration: 28 nM
Estimate against measurement, compound 4: 1.4-fold (0.15 log units) below; the range from low to high includes it.
By their numbers in this assay, from the lowest: compound 2; then compounds 3, 4 and 1 (each within the scatter of the next).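

In this assay iodo in place of chloro, on the aromatic carbon next to the ring sulfur, gives a 1.4-fold higher number from compound 3 to compound 4 (0.15 log units; within the scatter) and so no readable difference. For the compounds shown here, this is the first view of this position, and the two halogens read alike there, despite the much larger iodine atom. No supporting measurement bears on why the two read alike.

Still open, on these data alone, is how this position responds to something other than a halogen, such as an amine or a nitrile. As far as these compounds go, whether the same holds with another group in place of the 2-methylphenyl group also remains open.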